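Sulfonamide threonine amides with long alkyl chains on SiHa cells

The source may hold more compounds than are shown below. What is called first, only, known or untested is meant among the compounds shown, and "the series" means these compounds.

Measured so far, in a functional assay on SiHa cells (Homo sapiens) for cytotoxicity, read by MTT assay, with a stated time of 48 h; on this read-out lower numbers stand for stronger inhibition and higher numbers for weaker inhibition:
Compound 1 `CCCCCCCCCCCCCCNC(=O)[C@@H](NS(=O)(=O)c1ccc(C)cc1)[C@@H](C)O` gives 19200 nM.
Compound 2 `CCCCCCCCCCCCCCNC(=O)[C@@H](NS(=O)(=O)c1cccs1)[C@@H](C)O` gives 20400 nM.
Compound 3 `CCCCCCCCCCCCCCCCCCNC(=O)[C@@H](NS(=O)(=O)c1ccc(C)cc1)[C@@H](C)O` gives 29800 nM.

Compound 4 `CCCCCCCCCCCCCCCCCCNC(=O)[C@@H](NS(=O)(=O)c1cccs1)[C@@H](C)O` is not yet measured in this assay. It differs from compound 3 by thiophen-2-yl in place of 4-methylphenyl on a sulfonyl sulfur. The same change is found between compound 1 and compound 2, where it is thiophen-2-yl in place of 4-methylphenyl on a sulfonyl sulfur, and there it gave a 1.1-fold higher number from compound 1 to compound 2 (0.03 log units; within the scatter). The two cores differ by butyl in place of hydrogen on a saturated chain carbon, ten or more bonds along the chain from an amide-type nitrogen, a change that gave a 1.6-fold higher number from compound 1 to compound 3 (0.19 log units; within the scatter). Among the measured compounds shown here, both steps lie within the scatter, so the two changes appear to leave this assay largely untouched here, though only three compounds support this.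

The step from compound 3 to compound 4 is therefore expected to be about a 1.1-fold higher number from compound 3 to compound 4 (0.03 log units; within the scatter), resting on the near-flat step a 1.1-fold higher number from compound 1 to compound 2 (0.03 log units; within the scatter). For compound 4 the estimate in this assay is 32000 nM, expected between 16000 nM and 64000 nM.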

Compound 4, half-maximal inhibitory concentration: > 200000 nM
Compound 4: only a limit was reported; the forecaster's own chance of this, stated with the estimate: 5%; middle value at least 6.2-fold (0.79 log units) from the limit.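

In this assay compound 4 gives > 200000 nM, which is a limit of the assay and not a number. Thiophen-2-yl in place of 4-methylphenyl gives an at least 6.7-fold higher number from compound 3 to compound 4 (0.82 log units; beyond the scatter), so this change does not carry over unaltered from the core of compound 1 to the core of compound 3: the same change on two cores in this assay, a 1.1-fold higher number (0.03 log units; within the scatter) from compound 1 to compound 2 and an at least 6.7-fold higher number (0.82 log units; beyond the scatter) from compound 3 to compound 4, at least 6.3-fold (0.80 log units) apart, beyond the scatter of two such steps Read along the chain, the butyl change gives an at least 9.8-fold higher number from compound 2 to compound 4 (0.99 log units; beyond the scatter), so the two changes do not behave independently in this set, though a single pair of cores does not show how general this is, and the full size of both steps stays unknown: the same change on two cores in this assay, a 1.6-fold higher number (0.19 log units; within the scatter) from compound 1 to compound 3 and an at least 9.8-fold higher number (0.99 log units; beyond the scatter) from compound 2 to compound 4, at least 6.3-fold (0.80 log units) apart, beyond the scatter of two such steps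

Open, from the compounds shown here alone, is whether a phenyl or furan-2-yl group on the sulfonyl sulfur of the core of compound 3 behaves like thiophen-2-yl. Also open, going by these compounds, is how a chain of intermediate length, or a still longer chain, behaves with thiophen-2-yl.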